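Swapping Acetamido for Chloromethyl on a Shared Core

The source may report more compounds than this note shows. Statements on the series, on what has been measured and on what is new or still open speak of the compounds shown alone.

The measured compounds, tested in a toxicity assay on CCRF-CEM cells (Homo sapiens) for cytotoxicity; a higher number here means that more compound is tolerated, a lower number that less compound is tolerated:
- compound 1, `CC(=O)Nc1cccc2c1nc(-c1c(F)cccc1F)n2Cc1c(F)cccc1F`: 39.3 uM
- compound 2, `CN(C)c1cccc2c1nc(-c1c(F)cccc1F)n2Cc1c(F)cccc1F`: > 100 uM, a limit of this assay rather than a number
- compound 3, `N#Cc1cccc2c1nc(-c1c(F)cccc1F)n2Cc1c(F)cccc1F`: 26.7 uM

All three share one core and differ only in the group on one aromatic carbon. Among the two plain numbers, compound 1 stands highest, but its gap to compound 3 is within the scatter, so the two cannot be ranked. For compound 2 the assay gave only a limit (the limit of > 100 uM in this assay, at which 1 of the 3 values shown sits).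

The unmeasured compound 4, `Fc1cccc(F)c1Cn1c(-c2c(F)cccc2F)nc2c(CCl)cccc21`, again changes that one group: chloromethyl in place of acetamido on an aromatic carbon.

Two measured steps start from the same acetamido group. Replacing it with dimethylamino gave an at least 2.5-fold higher number from compound 1 to compound 2 (0.40 log units; beyond the scatter), while replacing it with cyano gave a 1.5-fold lower number from compound 1 to compound 3 (0.17 log units; within the scatter). Neither step involves chloromethyl, so the direction for compound 4 is uncertain; a step of modest size is plausible either way. For compound 4 the estimate is 20 uM, in the range 5 uM to 60 uM, which would be the expected step of a 2.0-fold lower number from compound 1 to compound 4 (0.29 log units; within the scatter).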

Compound 4, half-maximal toxic concentration: 13.4 uM
Compound 4: the middle estimate sits 1.5-fold (0.17 log units) above what was measured; low and high end bracket the measured number.
By their numbers in this assay, from the lowest: compounds 4, 3 and 1 (each within the scatter of the next, the first and the last beyond it). At a limit, above all of these: compound 2.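

In this assay, chloromethyl is the only group shown whose step down from acetamido lies beyond the scatter, a 2.9-fold lower number from compound 1 to compound 4 (0.47 log units; beyond the scatter), so with dimethylamino on the upward side, changes at this aromatic carbon now move the number clearly in both directions from compound 1. Chloromethyl and cyano cannot be told apart here, with a 2.0-fold lower number from compound 3 to compound 4 (0.30 log units; within the scatter). The widest step shown is an at least 7.4-fold lower number from compound 2 to compound 4 (0.87 log units; beyond the scatter), and its true size remains unknown, since compound 2 gave only a limit rather than a number: the limit of > 100 uM in this assay, at which 1 of the 4 values shown sits.

The compounds shown leave open whether a plain methyl or a bromomethyl at this carbon would give a number like that of compound 4. They also leave open whether a primary amine or a carboxylic acid there would reach the limit seen for compound 2.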